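Hydroxy in Place of Ethyl: Expected Cytotoxicity of Compound 3

This account rests on a few compounds, and the source may have more. Where it says the series, first, only, none or still open, it means among the compounds named here.

Measured compounds:
compound 1 `COc1nc2ccc(Br)cc2cc1C(c1ccccc1)n1cc(-c2ccccc2F)nn1`: 3.97%
compound 2 `CCCCCc1cn(C(c2ccccc2)c2cc3cc(Br)ccc3nc2OC)nn1`: -2%

In an ADME assay on HEK293 cells (Homo sapiens) for cytotoxicity, read by sulforhodamine B assay, with a stated time of 48 h, tested at 10 uM (a lower number here means less inhibition, a higher number more inhibition at the concentration tested (going by the name of the read-out)), compound 1 gives 3.97%, and compound 2 gives -2%. Compound 2 has the lowest of the two numbers, yet the step of a number 6 percentage points lower from compound 1 to compound 2 (within the scatter) lies within the scatter, so the two compounds cannot be told apart on this read-out. Compound 3 `COc1nc2ccc(Br)cc2cc1C(c1ccccc1)n1cc(CCCO)nn1` differs from compound 2 by hydroxy in place of ethyl on a saturated chain carbon, three bonds along the chain from an aromatic carbon. Within the data shown here, the only measured step, a number 6 percentage points lower from compound 1 to compound 2 (within the scatter), concerns a different part of the molecule and produced no change beyond the scatter; no measured step shows the change from ethyl to hydroxy. Among the measured compounds shown here, with both measured numbers close to zero and the single known step flat, the expected step of a number 3 percentage points higher from compound 2 to compound 3 (within the scatter) is none beyond the scatter. Compound 3 is therefore estimated at 1%, with a range from -10% to 12%.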

Compound 3, a percentage reported as inhibition, at one concentration (the size of the read-out at that concentration, not a potency): 27.4%
Beside the measured number, compound 3's estimate is 26.4 percentage points below it; measured number outside the range, above it.
By their numbers in this assay, from the lowest: compounds 2 and 1 (each within the scatter of the next); then compound 3.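

In this assay, the group at this place on the shared core can shift the number: hydroxy in place of ethyl on a saturated chain carbon, three bonds along the chain from an aromatic carbon, gives a number 29.4 percentage points higher from compound 2 to compound 3 (beyond the scatter) and is the first step of this size among these compounds. Set against 2-fluorophenyl, the 3-hydroxypropyl group gives a number 23.4 percentage points higher from compound 1 to compound 3 (beyond the scatter) while pentyl gave only a number 6 percentage points lower from compound 1 to compound 2 (within the scatter) so, among these three compounds, the all-carbon chain stays level with the aryl group and the chain carrying hydroxy stands apart. Nothing available explains why this change moves the number.

From the compounds shown here alone, whether a 2-hydroxyethyl group or a longer hydroxy-bearing chain would give a similar number stays open. So does the effect of an amine or a carboxylic acid in place of the hydroxy.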